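Cyclohexyl in Place of Benzyl on the Thiourea Nitrogen

The compounds below may be only part of what the source reports. "The series", "measured", "known", "first", "only" and "open" are said of these compounds alone.

Within the data shown here, compound 2 `S=C(NCc1ccccc1)N/N=C/c1cccc2ccccc12` gives 270 nM in a functional assay on B16 cells (Mus musculus), read by spectrophotometry, with a stated time of 3 days (a lower number here means a stronger inhibitor, a higher number a weaker inhibitor), and of the two numbers measured so far it stands next to compound 1 `Cc1ccccc1NC(=S)N/N=C/c1cccc2ccccc12`, which gives 490 nM; the move a 1.8-fold lower number from compound 1 to compound 2 (0.26 log units; within the scatter) lies within the scatter. Compound 3 `S=C(N/N=C/c1cccc2ccccc12)NC1CCCCC1` carries cyclohexyl in place of benzyl on an amide-type nitrogen. Among the measured compounds shown here, no measured step covers this particular change, and the only step known was small, so no shift beyond the scatter is expected in this assay. The number for compound 3 is therefore estimated at 350 nM, with a range from 120 nM to 1000 nM, which is expected to mean a 1.3-fold higher number from compound 2 to compound 3 (0.11 log units; within the scatter).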

Compound 3, half-maximal inhibitory concentration: 290 nM
Compound 3: the middle estimate sits 1.2-fold (0.08 log units) above what was measured, and the stated range covers the measured number.
By their numbers in this assay, from the lowest: compounds 2, 3 and 1 (each within the scatter of the next).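

In this assay, cyclohexyl on the amide-type nitrogen stands level with benzyl (a 1.1-fold higher number from compound 2 to compound 3 (0.03 log units; within the scatter)) and with 2-methylphenyl (a 1.7-fold lower number from compound 1 to compound 3 (0.23 log units; within the scatter)). A non-aromatic ring of carbon only therefore gives a number within the scatter of those from both aromatic groups, so an aromatic ring on this nitrogen is not required to keep the number in this range. All three groups shown contain only carbon and hydrogen, so it remains open whether an amine, a carboxylic acid or a longer chain here would shift the number. Nothing available explains why these numbers stay so close.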